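The source may hold more compounds than are shown below. What is called first, only, known or untested is meant among the compounds shown, and "the series" means these compounds.

Two analogues of a shared core have been measured in an assay on RBL-1 cells for inhibition of Polyunsaturated fatty acid 5-lipoxygenase (Rattus norvegicus); on this read-out lower numbers stand for stronger inhibition and higher numbers for weaker inhibition. Compound 1 `CCc1cccc(N2CCNC(=O)N2)c1` gives 13000 nM. Among the compounds with values here, compound 2 `O=C1NCCN(c2cccc(O)c2)N1` gives 32000 nM, the higher of the two numbers; the step of a 2.5-fold higher number from compound 1 to compound 2 (0.39 log units; beyond the scatter) is the only one available so far. Compound 2 therefore stands as the weaker of the two measured compounds, and nothing else measured sits near it.

Compound 3 `O=C1NCCN(c2cccc([N+](=O)[O-])c2)N1` is the next compound, not yet measured in this assay. It differs from compound 2 in one place: nitro in place of hydroxy on an aromatic carbon.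

Within the data shown here, no measured step exchanges a hydroxy for a nitro, so the only guide is the modest size of the one step that exists, from compound 1 to compound 2, which shows that changing the group on this aromatic carbon moves the number by only a modest amount. On that basis a step of similar or smaller size is expected in this assay for compound 3, with the direction open. The estimate for compound 3 is 20000 nM, within 6000 nM to 70000 nM, corresponding to an expected step of a 1.6-fold lower number from compound 2 to compound 3 (0.20 log units; within the scatter).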

Compound 3, half-maximal inhibitory concentration: 49000 nM
Estimate against measurement, compound 3: 2.5-fold (0.39 log units) below, within the range that was stated.
By their numbers in this assay, from the lowest: compound 1; then compounds 2 and 3 (each within the scatter of the next).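

In this assay the exchange of hydroxy for nitro on this aromatic carbon gives a 1.5-fold higher number from compound 2 to compound 3 (0.19 log units; within the scatter) and so does not separate the two groups, even though hydroxy carries a hydrogen-bond donor and nitro carries none. Ethyl does stand apart at this position: a 3.8-fold higher number from compound 1 to compound 3 (0.58 log units; beyond the scatter) adds to a 2.5-fold higher number from compound 1 to compound 2 (0.39 log units; beyond the scatter) and leaves compound 1 with the lowest number of the three, with both steps from it beyond the scatter and still modest in size. No measurement available for these compounds accounts for this pattern.

On these data alone, whether an amine, a carboxylic acid or a longer chain such as propyl on this aromatic carbon would stay in the same range, or would move the number further than ethyl does, remains open. As far as these compounds go, with only one carbon-only substituent among the three compounds, it is also open whether the lower number of compound 1 extends to other alkyl groups such as methyl or isopropyl.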